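The source may hold more compounds than are shown below. What is called first, only, known or untested is meant among the compounds shown, and "the series" means these compounds.

Compound 1 `Nc1cc(N)c2nc(-c3ccccc3)c(NCc3ccc(Cl)c(Cl)c3)nc2c1`; in a functional assay on SK-MEL-5 cells (Homo sapiens) for inhibition, read by sulforhodamine B assay, with a stated time of 48 h (a lower number here means a stronger inhibitor of growth, a higher number a weaker inhibitor of growth), compound 1 gives 3470 nM.
Compound 2 `Nc1cc(N)c2nc(-c3ccccc3)c(NCc3ccc(F)cc3)nc2c1`; in this assay compound 2 gives 1860 nM.
Compound 3 `COc1ccc(CNc2nc3cc(N)cc(N)c3nc2-c2ccccc2)cc1`; in this assay compound 3 gives 17800 nM.

Compound 2 has the lowest of the three numbers, but a 1.9-fold lower number from compound 1 to compound 2 (0.27 log units; within the scatter) lies within the scatter, so only compound 3 stands apart, as shown by a 9.6-fold higher number from compound 2 to compound 3 (0.98 log units; beyond the scatter). Compound 4 `Nc1cc(N)c2nc(-c3ccccc3)c(Sc3ccc(F)cc3)nc2c1` differs from compound 2 by (4-fluorophenyl)sulfanyl in place of (4-fluorobenzyl)amino on an aromatic carbon. Within the data shown here, no measured step touches this part of the structure; a 5.1-fold higher number from compound 1 to compound 3 (0.71 log units; beyond the scatter) and the other steps vary only the ring attached to the chain. The basis for an expectation is therefore thin. Compound 4 is expected near 3500 nM, with a range from 900 nM to 14000 nM. This estimate means a step of a 1.9-fold higher number from compound 2 to compound 4 (0.27 log units; within the scatter) in this assay, expected to fall within the scatter.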

Compound 4, concentration for 50% growth inhibition: 15500 nM
Compound 4: middle estimate off by 4.4-fold (0.65 log units), on the low side, and the stated range ends below it.
By their numbers in this assay, from the lowest: compounds 2 and 1 (each within the scatter of the next); then compounds 4 and 3 (each within the scatter of the next).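

In this assay, among these compounds, (4-fluorophenyl)sulfanyl in place of (4-fluorobenzyl)amino gives an 8.3-fold higher number from compound 2 to compound 4 (0.92 log units; beyond the scatter), so this position next to the ring nitrogen responds to a change of the link itself, which the earlier steps on the ring substituent left untouched. The entering group has sulfur and no hydrogen-bond donor, but this single step cannot tell which difference from the leaving group matters. Nothing available here explains the step.

On these data alone, whether an ether oxygen link or a longer chain at this carbon would track compound 2 or compound 4 stays open. So does whether methoxy or dichloro on the ring would shift the sulfanyl series as it did the amino series.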